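Swapping a Benzyl Group for an Aryl Ring on Compound 3

The compounds below may be only part of what the source reports. "The series", "measured", "known", "first", "only" and "open" are said of these compounds alone.

In an ADME assay on L02 cells (Homo sapiens) for inhibition, read by CCK-8 assay, with a stated time of 48 h (on this read-out higher numbers stand for weaker inhibition of growth and lower numbers for stronger inhibition of growth), three compounds built on one shared core have been measured. Compound 1 `Cc1ccccc1Nc1nc(NCc2ccccc2)ncc1Cl` gives only > 100000 nM, which is a limit of the assay rather than a number; it sits at the limit of > 100000 nM in this assay, at which 1 of the 3 values shown sits. Compound 2 `Cc1ccccc1Nc1nc(Nc2ccc(N3CCNCC3)cn2)ncc1Cl` gives 1850 nM. Compound 3 `CN1CCN(c2ccc(Nc3ncc(Cl)c(NCc4ccccc4)n3)nc2)CC1` gives 20300 nM, the higher of the two numbers, and the gap to compound 2 lies beyond the usual scatter, so compound 3 is the weaker growth inhibitor of the two.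

Compound 4 `CCc1ccc(Nc2nc(Nc3ccc(N4CCN(C)CC4)cn3)ncc2Cl)cc1` keeps the rest of compound 3 but carries 4-ethylphenyl in place of benzyl on a nitrogen on an aromatic ring. The closest comparison is compound 2, which likewise carries an aromatic ring on the amine nitrogen and whose value in this assay sits well below that of compound 3. On that basis a step of a 5.8-fold lower number from compound 3 to compound 4 (0.76 log units; beyond the scatter) is expected, toward stronger inhibition. The estimated value for compound 4 in this assay is 3500 nM, expected to fall between 900 nM and 14000 nM.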

Compound 4, concentration for 50% growth inhibition: 12100 nM
Beside the measured number, compound 4's estimate is 3.5-fold (0.54 log units) below it, within the range that was stated.
By their numbers in this assay, from the lowest: compound 2; then compounds 4 and 3 (each within the scatter of the next). At a limit, above all of these: compound 1.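

Placing 4-ethylphenyl instead of benzyl on this nitrogen gives, in this assay, a 1.7-fold lower number from compound 3 to compound 4 (0.22 log units; within the scatter), so the two compounds cannot be told apart on this read-out. At this position, then, exchanging benzylamino for (4-ethylphenyl)amino, which puts the aromatic ring directly on the amine nitrogen, is not enough to produce a clear shift in growth inhibition of these cells. None of the information available bears on why this change makes so little difference.

Going by these compounds, it remains open whether any other group on this nitrogen would move the number beyond the scatter. A plain phenyl ring, or a phenyl ring carrying an amine or a carboxylic acid in place of the ethyl group, could behave quite differently here.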